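This account rests on a few compounds, and the source may have more. Where it says the series, first, only, none or still open, it means among the compounds named here.

Compound 2 `COc1ccc(N(CC(=O)NCCCSc2ccccc2)C(=O)CNC(=O)OC(C)(C)C)cc1` is built on the same core as compound 1 `COc1ccc(N(CC(=O)NCCCSc2ccccc2)C(=O)C#Cc2ccccc2)cc1`, the two differing only in the group on the carbonyl carbon. In a functional assay on A-431 cells (Homo sapiens) for cytotoxicity, read by MTT assay, with a stated time of 24 h (a higher number here means a weaker inhibitor, a lower number a stronger inhibitor), compound 1 gives only a limit of the assay, >= 100000 nM. In this assay compound 2 also gives only a limit, >= 100000 nM. Both values sit at the limit of >= 100000 nM in this assay, at which 2 of the 2 values shown sit, so the step that the two limits leave unreadable from compound 1 to compound 2 has no readable size, and neither compound can be called weaker or stronger than the other.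

Compound 3 `COc1ccc(N(CC(=O)NCCCSc2ccccc2)C(=O)c2ccccc2)cc1` differs from compound 2 by phenyl in place of ((tert-butoxycarbonyl)amino)methyl on a carbonyl carbon. For the measured compounds named here, no measured step in this set shows what exchanging the group on this carbonyl carbon for a phenyl does, since the only measured exchange there ended in two limits. The expectation for compound 3 therefore rests on those limits alone, and the step of a number no higher from compound 2 to compound 3 (the limit leaves the size open) is expected to be none beyond the scatter. Compound 3 is thus estimated at 100000 nM, within a range from 30000 nM to 300000 nM.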

Compound 3, half-maximal inhibitory concentration: >= 100000 nM
Compound 3: only a limit was reported; the forecaster's own chance of this, stated with the estimate: 80%; the middle value sits exactly at the limit.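

Compound 3 gives >= 100000 nM in this assay as well, and this is only a limit. The steps among compound 1, compound 2 and compound 3 therefore cannot be read. The compounds shown leave open which group on this carbonyl carbon, if any, would give a readable value.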